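The source may hold more compounds than are shown below. What is called first, only, known or untested is meant among the compounds shown, and "the series" means these compounds.

In a functional assay on KYSE-410 cells (Homo sapiens) for antiproliferative activity, read by MTT assay, with a stated time of 72 h (a higher number here means a weaker inhibitor, a lower number a stronger inhibitor), three compounds built on one shared core have been measured. Compound 1 `O=C(Nc1cccc(F)c1)c1cc(=O)[nH]c2cc(Br)ccc12` gives 7300 nM, and compound 3 `O=C(Nc1cccc(F)c1)c1cc(=O)[nH]c2cc(-c3ccsc3)ccc12` gives 4300 nM. Compound 2 `O=C(Nc1cc(F)cc(F)c1)c1cc(=O)[nH]c2cc(F)ccc12` is recorded at > 20000 nM, which is a limit of the assay and not a number. Within the data shown here, that leaves only two numbers in the set, and compound 3 stands level with compound 1, since the single step joining them is a 1.7-fold lower number from compound 1 to compound 3 (0.23 log units; within the scatter).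

Compound 4 `O=C(Nc1cccc(F)c1)c1cc(=O)[nH]c2cc(-c3ccc(F)nc3)ccc12` keeps the core and the amide side of compound 3, but carries 6-fluoropyridin-3-yl in place of thiophen-3-yl on an aromatic carbon. Among the measured compounds shown here, the only measured step at this place is the one already given, bromo to thiophen-3-yl, and its size lies within the scatter. For the measured compounds named here, no measured pair exchanges one aromatic ring for another here, so this evidence is thin, and no shift beyond the scatter is expected from it. The expected change is a 1.1-fold lower number from compound 3 to compound 4 (0.03 log units; within the scatter). The estimate for compound 4 is 4000 nM, with an expected range from 1300 nM to 12000 nM.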

Compound 4, half-maximal inhibitory concentration: > 20000 nM
Compound 4 gave a limit, no number (the forecaster's own chance of this, stated with the estimate: 10%); at least 5.0-fold (0.69 log units) between middle value and limit.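

In this assay compound 4 stands at a limit of the assay and not at a number, so this aromatic carbon can be read in one direction only. Even so, the position proves sensitive to the group it carries, which the earlier exchange of bromo for thiophen-3-yl, within the scatter, did not show: 6-fluoropyridin-3-yl in place of thiophen-3-yl gives an at least 4.6-fold higher number from compound 3 to compound 4 (0.66 log units; beyond the scatter), and 6-fluoropyridin-3-yl in place of bromo gives an at least 2.7-fold higher number from compound 1 to compound 4 (0.43 log units; beyond the scatter). Both steps rest on that limit, so their full size stays unknown, and the set offers little resolution at the weak end: the limit of > 20000 nM in this assay, at which 2 of the 4 values shown sit.

The compounds shown leave open whether the change follows the six-membered ring itself, its ring nitrogen or its fluorine, since 6-fluoropyridin-3-yl differs from thiophen-3-yl in all three at once. A plain phenyl or an unsubstituted pyridin-3-yl on this carbon would separate those readings, and an amine such as morpholine would show how the position answers to a group joined through nitrogen.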